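Dropping the Chloro Group: From Compound 3 to Compound 4

The source may report more compounds than this note shows. Statements on the series, on what has been measured and on what is new or still open speak of the compounds shown alone.

Three amides built on one shared core have been tested in a functional assay on HCT-116 cells (Homo sapiens) for antiproliferative activity, read by MTT assay, with a stated time of 48 h; on this read-out higher numbers stand for weaker inhibition and lower numbers for stronger inhibition. Compound 1 `Cc1cccc(C(=O)Nc2cc(Sc3ncn[nH]3)c(O)c3ccccc23)c1` carries a 3-methylphenyl on the carbonyl carbon, compound 2 `COc1ccc(C(=O)Nc2cc(Sc3ncn[nH]3)c(O)c3ccccc23)cc1` a 4-methoxyphenyl, and compound 3 `O=C(/C=C/c1ccc(Cl)cc1)Nc1cc(Sc2ncn[nH]2)c(O)c2ccccc12` a 2-(4-chlorophenyl)ethenyl. In this assay compound 1 gives > 100000 nM, which is a limit of the assay and not a number. Compound 2 likewise gives only the limit > 100000 nM. Compound 3 too reaches only the limit > 100000 nM. Because of the limit of > 100000 nM in this assay, at which 3 of the 3 values shown sit, none of the three steps between these compounds can be read: a step that the two limits leave unreadable from compound 1 to compound 2, a step that the two limits leave unreadable from compound 1 to compound 3 and a step that the two limits leave unreadable from compound 2 to compound 3 are all of unknown size. Going by the values given here, compound 3 thus stands at the limit, with no measured compound placed either side of it.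

Compound 4 `O=C(/C=C/c1ccccc1)Nc1cc(Sc2ncn[nH]2)c(O)c2ccccc12` differs from compound 3 in one place only: hydrogen in place of chloro on an aromatic carbon. No measured step bears on this change, since every step shown is unreadable, and all three compounds, despite widely differing groups on the carbonyl carbon, sit at the same limit. Compound 4 is therefore expected to remain at the limit as well, with the step that the limit leaves unreadable from compound 3 to compound 4 estimated as essentially none. The estimate for compound 4 is 150000 nM, between 40000 nM and 500000 nM.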

Compound 4, half-maximal inhibitory concentration: > 100000 nM
Compound 4: a limit, no number (the forecaster's own chance of this, stated with the estimate: 85%); the middle value is on the limit's open side.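

None of the steps from compound 1, compound 2 or compound 3 to compound 4 can be read in this assay, so their sizes stay unknown: the limit of > 100000 nM in this assay, at which 4 of the 4 values shown sit.

The compounds shown leave open how far each lies past that limit, and so whether hydrogen in place of chloro, or any change of the group on the carbonyl carbon, makes any difference.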